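This account rests on a few compounds, and the source may have more. Where it says the series, first, only, none or still open, it means among the compounds named here.

Measured compounds:
Compound 1 `COc1ccc(Br)cc1Nc1cc(NC(=O)Nc2c(Cl)cccc2Cl)ncn1`: 33%
Compound 2 `COc1ccc(OC)c(Nc2cc(NC(=O)Nc3c(Cl)cccc3Cl)ncn2)c1`: 81.7%
Compound 3 `COc1ccc(C(F)(F)F)cc1Nc1cc(NC(=O)Nc2c(Cl)cccc2Cl)ncn1`: 60.1%

In a functional assay on NCI-H226 cells (Homo sapiens) for inhibition, read by MTT assay, with a stated time of 48 h, tested at 10 uM (on this read-out lower numbers stand for less inhibition and higher numbers for more inhibition at the one concentration tested (going by the name of the read-out)), compound 1 gives 33%, the lowest of the three numbers. Going a number 48.7 percentage points higher from compound 1 to compound 2 (beyond the scatter) is the largest measured change, and going a number 27.1 percentage points higher from compound 1 to compound 3 (beyond the scatter) is a modest one. Between the two higher compounds, going a number 21.6 percentage points lower from compound 2 to compound 3 (beyond the scatter).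

Compound 4 `Cc1ccc(Nc2cc(NC(=O)Nc3c(Cl)cccc3Cl)ncn2)cc1C` differs from compound 1 in a larger way than either measured step: 3,4-dimethylphenyl in place of 5-bromo-2-methoxyphenyl on a nitrogen on an aromatic ring. Both measured steps swapped a single group on the ring that is attached to this nitrogen, and both moved the read-out upward from compound 1. Within the data shown here, no measured step swaps the whole ring, so the two steps guide only loosely. Since every change made so far from compound 1 raised inhibition, compound 4 is expected to rise as well, most likely by a modest amount, though a flat result within the scatter cannot be excluded. For compound 4 the estimate is 55%, from 30% to 80%. The expected step is a number 22 percentage points higher from compound 1 to compound 4 (beyond the scatter).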

Compound 4, a percentage reported as inhibition, at one concentration (the size of the read-out at that concentration, not a potency): 41.3%
Compound 4: middle estimate off by 13.7 percentage points, on the high side; low and high end bracket the measured number.
By their numbers in this assay, from the lowest: compounds 1 and 4 (each within the scatter of the next); then compound 3; then compound 2.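

Going a number 8.3 percentage points higher from compound 1 to compound 4 (within the scatter) in this assay shows that the whole group on this nitrogen can be exchanged, 3,4-dimethylphenyl for 5-bromo-2-methoxyphenyl, with its oxygen and bromine gone, and the read-out still stays level. So not every change from compound 1 brings a rise: the single-group swaps in compound 2 and compound 3 moved the number beyond the scatter, while this larger exchange does not, and among these compounds the amount of structure replaced does not set the size of the step. Nothing measured here explains why this exchange leaves the number in place.

As far as these compounds go, with two methyl groups entering and two other groups leaving at once, the contribution of each one alone stays unknown. Also open, from the compounds shown here alone, is where this series would land with an amine or a carboxylic acid on the same ring.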